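The source may hold more compounds than are shown below. What is called first, only, known or untested is meant among the compounds shown, and "the series" means these compounds.

Measured so far in a functional assay on the whole organism (strain Wister albino) for inhibition, with Rattus norvegicus as the target, read by paw edema, with stated times of 1 h and 4 h, at a dose of 50 mg/kg by the intraperitoneal route; a lower number here means less inhibition, a higher number more inhibition at the dose given (going by the name of the read-out):

Compound 1 `CN1C/C(=C\c2ccc(Br)cc2)C(=O)[C@]2(C1)[C@@H](c1ccc(Br)cc1)CN(C)[C@@]21C(=O)Nc2ccccc21` gives 66.8%.
Compound 2 `CN1C/C(=C\c2ccc(Br)cc2)C(=O)[C@]2(C1)[C@@H](c1ccc(Br)cc1)CN(C)[C@@]21C(=O)N(C)c2ccccc21` gives 46.8%.
Compound 3 `CN1C/C(=C\c2ccc(Cl)cc2)C(=O)[C@]2(C1)[C@@H](c1ccc(Cl)cc1)CN(C)[C@@]21C(=O)Nc2ccccc21` gives 42.2%.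

Compound 3 stands at the low end of the three numbers in this assay: compound 2 lies within the scatter of it, while compound 1 lies beyond the scatter above it. Within the data shown here, compound 3 and compound 1 differ only in the halogen on the two aryl groups, chlorine against bromine, and no single step connects them to any other pair, so their two values are all that can be said of that exchange.

Compound 4 `CN1C/C(=C\c2ccc(Cl)cc2)C(=O)[C@]2(C1)[C@@H](c1ccc(Cl)cc1)CN(C)[C@@]21C(=O)N(C)c2ccccc21` is compound 3 with one change: methyl in place of hydrogen on an amide-type nitrogen in a ring. The same change has been measured once, on the bromo pair, as a number 20 percentage points lower from compound 1 to compound 2 (beyond the scatter). Among the measured compounds shown here, that is the only measured step that bears on the present one, so the expectation rests on a single pair. Carrying it over, compound 4 is expected to sit below compound 3 by a step of comparable size, a number 19.2 percentage points lower from compound 3 to compound 4 (beyond the scatter), in this assay. Compound 4 is therefore estimated at 23% in this assay, with a range of 9% to 37%.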

Compound 4, a percentage reported as inhibition, in the whole organism at one dose (the size of the read-out at that dose, not a potency): 45.7%
Beside the measured number, compound 4's estimate is 22.7 percentage points below it; the measured number lies above the stated range.
By their numbers in this assay, from the lowest: compounds 3, 4 and 2 (each within the scatter of the next); then compound 1.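

In this assay, methyl in place of hydrogen on the amide-type nitrogen in a ring does not have one fixed outcome: on the chloro pair it gives a number 3.5 percentage points higher from compound 3 to compound 4 (within the scatter), so the loss seen on the bromo pair does not recur. On the two pairs available, the outcome of this change at this position differs with the core that carries it: the same change on two cores in this assay, a number 20 percentage points lower (beyond the scatter) from compound 1 to compound 2 and a number 3.5 percentage points higher (within the scatter) from compound 3 to compound 4, 23.5 percentage points apart, beyond the scatter of two such steps With only the bromo pair showing a step beyond the scatter, that step cannot be taken as a rule for methyl on this nitrogen, and the chloro pair shows that the amide hydrogen can be replaced here with no change beyond the scatter.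

Which of the two outcomes is the more usual one stays open, and a third pair with the same change, carrying fluorine or methoxy on the two aryl groups, would help to settle it. Also open, going by these compounds, is how a group larger than methyl on the same nitrogen, such as ethyl or benzyl, would read in this assay on either the chloro or the bromo core.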